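This account rests on a few compounds, and the source may have more. Where it says the series, first, only, none or still open, it means among the compounds named here.

Of the compounds shown here, three sharing one core have been tested in a functional assay on the whole organism for inhibition, with Brassica napus as the target, with a stated time of 72 h, tested at 100 mg/L; on this read-out higher numbers stand for more inhibition of growth at the one concentration tested and lower numbers for less inhibition of growth. Compound 2 `COc1cc(C)nc2n/c(=N/C(=O)c3c(-c4ccc(Cl)cc4Cl)noc3C)sn12` gives 80.6%, the highest of the three. Compound 3 `CSc1cc(C)nc2n/c(=N/C(=O)c3c(-c4ccc(Cl)cc4Cl)noc3C)sn12` gives 62.8%, and compound 1 `Cc1cc(O)nc(NC(=S)NC(=O)c2c(-c3ccc(Cl)cc3Cl)noc2C)n1` gives 52.3%. Compound 4 `COc1cc(SC)nc2n/c(=N/C(=O)c3c(-c4ccc(Cl)cc4Cl)noc3C)sn12` has not yet been measured. It differs from compound 2 in one place: methylsulfanyl in place of methyl on an aromatic carbon. Among the compounds with values here, the one measured step that bears on this change is a number 17.8 percentage points lower from compound 2 to compound 3 (beyond the scatter), in which a methylsulfanyl group likewise entered the same ring. Within the data shown here, a drop of similar or somewhat smaller size is therefore expected, because the only comparable change gave a number 17.8 percentage points lower from compound 2 to compound 3 (beyond the scatter). The step expected is a number 12.6 percentage points lower from compound 2 to compound 4 (beyond the scatter). Compound 4 is estimated at 68%, with a range from 50% to 85%.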

Compound 4, percent growth inhibition at one concentration: 75.8%
For compound 4 the middle estimate is 7.8 percentage points below the measured one; low and high end bracket the measured number.
By their numbers in this assay, from the lowest: compound 1; then compound 3; then compounds 4 and 2 (each within the scatter of the next).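

Methylsulfanyl in place of methyl on this aromatic carbon gives a number 4.8 percentage points lower from compound 2 to compound 4 (within the scatter) in this assay. The earlier replacement of methoxy gave a number 17.8 percentage points lower from compound 2 to compound 3 (beyond the scatter), so the loss seen there does not carry over to this position and this change. No measurement shown accounts for the difference between these two steps.

An amine or a longer chain such as ethylsulfanyl on this carbon is not among the compounds shown. From the compounds shown here alone, how either would compare with the methyl of compound 2 remains open.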